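A few compounds are considered here, and "the series" means these few. Any claim that something is new, unique, unknown or untested is made for them only; others in the source may bear on it.

Measured compounds, each in an assay on CHO cells for binding affinity to metabotropic glutamate receptor 2 (Rattus norvegicus); a higher number here means a weaker inhibitor, a lower number a stronger inhibitor:

Compound 1, `N[C@]1(C(=O)O)[C@H]2[C@@H](C[C@H]1OCCCc1ccccc1)[C@]2(F)C(=O)O`, gives 9.83 nM.
Compound 2, `N[C@]1(C(=O)O)[C@H]2[C@@H](C[C@H]1OCc1ccc(Cl)cc1Cl)[C@]2(F)C(=O)O`, gives 3.89 nM.
Compound 3, `N[C@]1(C(=O)O)[C@H]2[C@@H](C[C@H]1OCc1ccc(F)c(Cl)c1)[C@]2(F)C(=O)O`, gives 3.57 nM.

All three share one core and differ only in the group carried on the saturated chain carbon bound to an oxygen on a saturated carbon. Compound 3 has the lowest number of the three, but compound 2 lies within the scatter of it, so the two cannot be ranked; only compound 1 stands clearly apart, as seen in a 2.8-fold lower number from compound 1 to compound 3 (0.44 log units; beyond the scatter) and a 2.5-fold lower number from compound 1 to compound 2 (0.40 log units; beyond the scatter). The step between the two halogenated rings, a 1.1-fold lower number from compound 2 to compound 3 (0.04 log units; within the scatter), shows that swapping one substituted aromatic ring for another changed little.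

Compound 4, `N[C@]1(C(=O)O)[C@H]2[C@@H](C[C@H]1OCc1cccs1)[C@]2(F)C(=O)O`, is not yet measured. It differs from compound 3 in one place: thiophen-2-yl in place of 3-chloro-4-fluorophenyl on a saturated chain carbon bound to an oxygen on a saturated carbon. Going by the values given here, no measured step tests a five-membered ring here. The two aromatic replacements that were measured point to a small effect of ring identity, whereas the chain length in compound 1 mattered more. Compound 4 is therefore expected to land near compound 3, with some risk of a weaker number; the estimated step is a 2.2-fold higher number from compound 3 to compound 4 (0.35 log units; beyond the scatter). The estimate for compound 4 is 8 nM, within 3 nM to 25 nM.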

Compound 4, inhibition constant: 8.79 nM
For compound 4 the middle estimate is 1.1-fold (0.04 log units) below the measured one; the range from low to high includes it.
By their numbers in this assay, from the lowest: compounds 3 and 2 (each within the scatter of the next); then compounds 4 and 1 (each within the scatter of the next).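

In this assay, going by these compounds alone, thiophen-2-yl is the first five-membered ring seen at this place, and it separates from both halogenated rings (a 2.5-fold higher number from compound 3 to compound 4 (0.39 log units; beyond the scatter); a 2.3-fold higher number from compound 2 to compound 4 (0.35 log units; beyond the scatter)). Ring identity on this saturated chain carbon can therefore shift the number beyond the scatter, which the step between the two halogenated six-membered rings did not show, and the thiophen-2-yl compound cannot be told apart from the phenethyl compound (a 1.1-fold lower number from compound 1 to compound 4 (0.05 log units; within the scatter)). Nothing available here offers a measured explanation for these differences.

Compound 4 changes ring size, brings in sulfur and loses both halogens all at once, so the compounds shown cannot say which of these changes matters. An unsubstituted phenyl or a furan-2-yl ring on the same carbon would help pull these changes apart.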